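From hydroxy to acetamido on the amine side chain

The source may report more compounds than this note shows. Statements on the series, on what has been measured and on what is new or still open speak of the compounds shown alone.

Measured in a functional assay on MC-38 cells (Mus musculus) for antiproliferative activity, read by CCK-8 assay, with a stated time of 48 h; a lower number here means a stronger inhibitor, a higher number a weaker inhibitor:
Compound 1 `COc1ccc(/C=C\c2cc(OC)c(OC)c(OC)c2)cc1OCc1ccc(CNC(C)(C)C(=O)O)cc1`: > 10000 nM
Compound 2 `COc1ccc(/C=C\c2cc(OC)c(OC)c(OC)c2)cc1OCc1ccc(CNCCO)cc1`: 1200 nM

Compound 1 gives > 10000 nM, which is a limit and not a number. Among the measured compounds shown here, compound 2, at 1200 nM, therefore holds the only true number so far. Compound 3 `COc1ccc(/C=C\c2cc(OC)c(OC)c(OC)c2)cc1OCc1ccc(CNCCNC(C)=O)cc1` differs from it by acetamido in place of hydroxy on a saturated chain carbon, two bonds along the chain from an amine nitrogen. For the measured compounds named here, the sole measured step, an at least 8.3-fold lower number from compound 1 to compound 2 (0.92 log units; beyond the scatter), starts from a limit and swaps a different group, so compound 2 offers only a weak guide. The expected change in this assay is a 1.3-fold higher number from compound 2 to compound 3 (0.10 log units; within the scatter), with nothing beyond the scatter anticipated. For compound 3 the estimated value is 1500 nM, with an expected range of 400 nM to 6000 nM.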

Compound 3, half-maximal inhibitory concentration: 1800 nM
Estimate against measurement, compound 3: 1.2-fold (0.08 log units) below, within the range that was stated.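

Acetamido in place of hydroxy on a saturated chain carbon, two bonds along the chain from an amine nitrogen, gives a 1.5-fold higher number from compound 2 to compound 3 (0.18 log units; within the scatter) in this assay. At this position, then, hydroxy and the bigger acetamido cannot be told apart in this measurement. The other new step reads an at least 5.5-fold lower number from compound 1 to compound 3 (0.74 log units; beyond the scatter), but it starts from a limit and not a number, so its full size stays unknown: the limit of > 10000 nM in this assay, at which 1 of the 3 values shown sits.

Still open, on these data alone, is whether an amine or a longer chain in place of hydroxy would move the number beyond the scatter.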